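The compounds below may be only part of what the source reports. "The series", "measured", "known", "first", "only" and "open" are said of these compounds alone.

Compound 1 `O=C(/C(=C\c1c(O)cc(O)cc1O)SCc1ccc(Cl)cc1)c1ccc(Cl)cc1` is one of three analogues sharing a core in which a 2,4,6-trihydroxyphenyl ring sits on the double-bonded chain carbon. In a functional assay on DU-145 cells (Homo sapiens) for inhibition, read by trypan blue exclusion, with a stated time of 96 h (a higher number here means a weaker inhibitor of growth, a lower number a stronger inhibitor of growth), compound 1 gives only a limit, > 100000 nM. Compound 2 `O=C(/C(=C\c1c(O)cc(O)cc1O)Sc1ccc(Br)cc1)c1ccc(Cl)cc1`, carrying 4-bromophenyl in place of 4-chlorobenzyl on the sulfur, gives 50000 nM in this assay, a change of an at least 2.0-fold lower number from compound 1 to compound 2 (0.30 log units; that floor lies within the scatter). Compound 3 `Cc1ccc(S(=O)(=O)/C(=C/c2c(O)cc(O)cc2O)C(=O)c2ccc(Cl)cc2)cc1` likewise reaches only a limit, > 100000 nM. The step of an at least 2.0-fold higher number from compound 2 to compound 3 (0.30 log units; that floor lies within the scatter) and the step that the two limits leave unreadable from compound 1 to compound 3 are both bounded by that limit, (the limit of > 100000 nM in this assay, at which 2 of the 3 values shown sit), so compound 1 stands only at the edge of what this assay reports.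

Compound 4 `O=C(/C(=C\c1ccc[nH]1)SCc1ccc(Cl)cc1)c1ccc(Cl)cc1` differs from compound 1 in a different place altogether: 1H-pyrrol-2-yl in place of 2,4,6-trihydroxyphenyl on a double-bonded chain carbon bound to a double-bonded chain carbon. Within the data shown here, none of the measured steps touches this ring; each varies only the group on the sulfur, and all of them are at or within the scatter or unreadable. Among the measured compounds shown here, there is thus no measured step that bears on the change to compound 4, and no direction can be read from the data. Compound 4 is therefore expected to remain weak, with an estimate of 100000 nM ranging from 30000 nM to 300000 nM. This estimate implies an expected step of a number no higher from compound 1 to compound 4 (the limit leaves the size open).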

Compound 4, concentration for 50% growth inhibition: 10000 nM
For compound 4 the middle estimate is 10-fold (1.00 log units) above the measured one; measured number below the stated range.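

Putting 1H-pyrrol-2-yl in place of 2,4,6-trihydroxyphenyl gives an at least 10-fold lower number from compound 1 to compound 4 (1.00 log units; beyond the scatter) in this assay and is the first step shown that lies beyond the scatter, whereas the earlier steps, all on the group on the sulfur, lay within the scatter or could not be read. The hydroxyl groups of the 2,4,6-trihydroxyphenyl ring are therefore not required for the growth inhibition seen with compound 4, which carries a smaller ring, with 5 heavy atoms against 9 and 1 hydrogen-bond donor against 3. Going by these compounds, the full size of the step stays unknown because compound 1 gives only a limit: the limit of > 100000 nM in this assay, at which 2 of the 4 values shown sit.

On these data alone, whether the step follows from the loss of the hydroxyl groups or from the 1H-pyrrol-2-yl ring itself remains open, and an unsubstituted phenyl ring or a furan-2-yl ring at this place would help to separate the two. As far as these compounds go, it also remains open whether 1H-pyrrol-2-yl would bring a similar step alongside the 4-bromophenyl group of compound 2 or the (4-methylphenyl)sulfonyl group of compound 3.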